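Replacing 3-bromophenyl with a small alkene chain

The compounds below may be only part of what the source reports. "The series", "measured", "known", "first", "only" and "open" are said of these compounds alone.

Going by the values given here, in an ADME assay on MT4 cells (Homo sapiens) for cytotoxicity (on this read-out lower numbers stand for higher toxicity in this test and higher numbers for lower toxicity in this test), compound 2 (`FC(F)(F)c1cccc(NC(=S)Nc2cccc(Br)c2)c1`) gives 9200 nM as the only exact number so far. Compound 1 (`CC(=O)NC(=S)Nc1cccc(C(F)(F)F)c1`) stands at > 100000 nM and this is a limit of the assay, not a number. The two compounds differ in one place, and the measured step is large: an at least 10-fold lower number from compound 1 to compound 2 (1.03 log units; beyond the scatter) with 3-bromophenyl as the incoming group. Compound 3 (`C=C(C)CNC(=S)Nc1cccc(C(F)(F)F)c1`) loses that same group from the amide-type nitrogen and carries 2-methylprop-2-en-1-yl there instead (2-methylprop-2-en-1-yl in place of 3-bromophenyl on an amide-type nitrogen). Neither acetyl nor the new chain is an aromatic ring, so compound 1 is the closest guide, although one step is thin support. The expected result is a 3.8-fold higher number from compound 2 to compound 3 (0.58 log units; beyond the scatter) and so a shift towards lower toxicity, probably without the full reach of the measured step. Compound 3 is estimated at 35000 nM with 12000 nM to 100000 nM as the expected range.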

Compound 3, half-maximal cytotoxic concentration: 43000 nM
Beside the measured number, compound 3's estimate is 1.2-fold (0.09 log units) below it, and the stated range covers the measured number.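

On the amide-type nitrogen, this assay now gives an exact number for a group without a ring, and exchanging the 3-bromophenyl for this small chain gives a 4.7-fold higher number from compound 2 to compound 3 (0.67 log units; beyond the scatter). Two groups without an aromatic ring also prove not to be equivalent at this place, as 2-methylprop-2-en-1-yl in place of acetyl gives an at least 2.3-fold lower number from compound 1 to compound 3 (0.36 log units; beyond the scatter). That step has no exact size, since compound 1 is recorded only as a limit of the assay: the limit of > 100000 nM in this assay, at which 1 of the 3 values shown sits.

From the compounds shown here alone, it remains open whether the change from compound 2 to compound 3 follows from losing the aromatic ring or the bromine on it, a question that a plain phenyl group could help to separate. Going by these compounds, how a longer saturated chain, an amine or a carboxylic acid at this place would read also remains open.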